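Butyl for methoxy: splenocyte tolerance notes

The source may hold more compounds than are shown below. What is called first, only, known or untested is meant among the compounds shown, and "the series" means these compounds.

Compound 1 `Clc1ccc(-c2noc(Cc3c[nH]c4ccccc34)n2)cc1`: in an ADME assay on cells (Splenocyte, Mus musculus, strain BALB/c) for cytotoxicity, read by CCK-8 assay, with a stated time of 48 h (a lower number here means that less compound is tolerated, a higher number that more compound is tolerated), compound 1 gives 42800 nM.
Compound 2 `COc1ccc(-c2nc(Cc3c[nH]c4ccccc34)no2)cc1`: in this assay compound 2 gives > 50000 nM.
Compound 3 `COc1ccc(-c2nc(Cc3c[nH]c4ccccc34)no2)c(OC)c1`: in this assay compound 3 gives 9300 nM.

Compound 2 stands at the limit of > 50000 nM in this assay, at which 1 of the 3 values shown sits, a limit of the assay rather than a number. Going by the values given here, the one measured single-site step is an at least 5.3-fold lower number from compound 2 to compound 3 (0.73 log units; beyond the scatter), a methoxy added to compound 2. Compound 4 `CCCCc1ccc(-c2nc(Cc3c[nH]c4ccccc34)no2)cc1` differs from compound 2 by butyl in place of methoxy on an aromatic carbon. Among the compounds with values here, no measured step swaps one group for another at this position, so the direction is open; the only precedent shows that a change on this ring can lower the number. The expected step is an at least 1.6-fold lower number from compound 2 to compound 4 (0.22 log units; that floor lies within the scatter), with a fair chance that only a limit is reported again. Compound 4 is estimated at 30000 nM, between 10000 nM and 50000 nM.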

Compound 4, half-maximal cytotoxic concentration: 8200 nM
Compound 4: the middle estimate sits 3.7-fold (0.56 log units) above what was measured, and the stated range ends above it.
By their numbers in this assay, from the lowest: compounds 4 and 3 (each within the scatter of the next); then compound 1. At a limit, above all of these: compound 2.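

Butyl in place of methoxy gives an at least 6.0-fold lower number from compound 2 to compound 4 (0.78 log units; beyond the scatter) in this assay, so a swap at this position alone, with no second substituent on the ring, is enough to change the number beyond the scatter. The true size of this step cannot be read, since compound 2 stands at a limit of the assay and not at a number: the limit of > 50000 nM in this assay, at which 1 of the 4 values shown sits.

As far as these compounds go, whether the change follows the butyl chain itself or the loss of methoxy remains open. An ethyl group, a longer chain such as hexyl, or an amine at this place would help separate the two.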